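The source may report more compounds than this note shows. Statements on the series, on what has been measured and on what is new or still open speak of the compounds shown alone.

Working notes on the series.

Compound 1 `O=C(O)CCCCOc1ccc2c(=O)c(-c3ccc(O)cc3)coc2c1` gives 5000 nM in an assay (Cricetulus griseus) for inhibition of Monoamine oxidase (Homo sapiens); on this read-out lower numbers stand for stronger inhibition and higher numbers for weaker inhibition. Compound 2 `O=c1c(-c2ccc(O)cc2)coc2cc(OCCCCCCCCCO)ccc12` reaches only the assay limit of > 9000 nM in this assay, a limit and not a number (the limit of > 9000 nM in this assay, at which 1 of the 3 values shown sits). Compound 3 `C=CCCCCOc1ccc2c(=O)c(-c3ccc(O)cc3)coc2c1` gives 5000 nM in this assay and so stands level with compound 1 at the digits shown; the step of no change at the digits printed from compound 1 to compound 3 (within the scatter) lies within the scatter, and the step of an at least 1.8-fold lower number from compound 2 to compound 3 (0.25 log units; that floor lies within the scatter) rests on a limit whose floor also lies within the scatter.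

Compound 4 `O=C(O)COc1ccc2c(=O)c(-c3ccc(O)cc3)coc2c1` differs from compound 3 by carboxy in place of pent-4-en-1-yl on a saturated chain carbon bound to an oxygen on an aromatic ring. The measured steps exchange only the end of the chain while its length stays the same; none of them shortens the chain as this change does, so they bear on it only loosely. The step of no change at the digits printed from compound 1 to compound 3 (within the scatter) shows that carboxy against vinyl at a fixed chain length leaves the value unchanged within the scatter, which is the closest guide available here.

Compound 4 is therefore expected to give about 5000 nM in this assay, within 1500 nM to 16000 nM, the estimated step being no change at the digits printed from compound 3 to compound 4 (within the scatter).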

Compound 4, half-maximal inhibitory concentration: >> 9000 nM
Compound 4: a limit, no number (the forecaster's own chance of this, stated with the estimate: 30%); middle value at least 1.8-fold (0.25 log units) away from the limit.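

Compound 4 sits at a limit in this assay, not at a number: the limit of >> 9000 nM in this assay, at which 1 of the 4 values shown sits. For the compounds shown here, the step of an at least 1.8-fold higher number from compound 1 to compound 4 (0.25 log units; that floor lies within the scatter) is the first read on shortening the chain while the carboxy end stays, and an at least 1.8-fold higher number from compound 3 to compound 4 (0.25 log units; that floor lies within the scatter) runs the same way, so the level pair of compound 1 and compound 3 no longer speaks for every chain length at this position, though neither floor clears the scatter. The step between compound 2 and compound 4 cannot be read, both values being limits.

On these data alone, whether the read-out tracks chain length in one direction stays open, since compound 2, with its 8-hydroxyoctyl chain, also ends at a limit. Also open, as far as these compounds go, is how an amine or an amide at the end of the short chain would compare with carboxy here.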